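Thiourea ethers: benzoyl in place of benzyl

A few compounds are considered here, and "the series" means these few. Any claim that something is new, unique, unknown or untested is made for them only; others in the source may bear on it.

Compound 1 `NC(=S)Nc1cccc(Oc2ccccc2)c1` and compound 2 `NC(=S)Nc1cccc(OCc2ccccc2)c1` carry a short ether group on the shared core. In an ADME assay on Ava5 cells (Homo sapiens) for cytotoxicity (a higher number here means that more compound is tolerated, a lower number that less compound is tolerated), compound 1 gives only a limit, > 50000 nM. Compound 2 likewise gives only a limit, > 50000 nM. Compound 3 `NC(=S)Nc1cccc(OCCCCCOc2cccc(Cc3ccccc3)c2)c1`, with a longer ether chain leading to a second ring, is the only one of the three with a number in this assay: compound 3 gives 13000 nM. The other two values sit at the limit of > 50000 nM in this assay, at which 2 of the 3 values shown sit. Compound 4 `NC(=S)Nc1cccc(OCCCCCOc2cccc(C(=O)c3ccccc3)c2)c1` is not yet measured; it differs from compound 3 by benzoyl in place of benzyl on an aromatic carbon. Within the data shown here, no step between measured compounds is available, so this change is expected to stay within the scatter, with no clear direction. For compound 4 the estimated value in this assay is 15000 nM, between 6000 nM and 40000 nM. The expected step is small, a 1.2-fold higher number from compound 3 to compound 4 (0.06 log units; within the scatter).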

Compound 4, half-maximal cytotoxic concentration: 13000 nM
The estimate for compound 4 lay 1.2-fold (0.06 log units) above the measured number, and the stated range covers the measured number.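

In this assay, benzoyl in place of benzyl on an aromatic carbon, meta to a large group, gives no change at the digits printed from compound 3 to compound 4 (within the scatter). Among these compounds, this is the first step that can be read, and it shows that this position takes the added carbonyl, with its hydrogen-bond acceptor, without a shift beyond the scatter. Compounds 3 and 4 give numbers, while compounds 1 and 2 give only limits: the limit of > 50000 nM in this assay, at which 2 of the 4 values shown sit.

From the compounds shown here alone, whether an amine or a carboxylic acid on this aromatic carbon would move the number stays open. So does the outcome of a longer chain in the ether.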